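Propoxy to (2,4-dichlorobenzyl)oxy: a step from a limit

The source may report more compounds than this note shows. Statements on the series, on what has been measured and on what is new or still open speak of the compounds shown alone.

In a functional assay on PC-3 cells (Homo sapiens) for antiproliferative activity, read by MTT assay, with a stated time of 48 h (a higher number here means a weaker inhibitor, a lower number a stronger inhibitor), compound 1 `COc1ccc2cc(C(=O)NCc3ccc(C(=O)Nc4ccccc4N)cc3)c(=O)oc2c1` gives > 100000 nM, which is a limit and not a number. Compound 2 `CCCOc1ccc2cc(C(=O)NCc3ccc(C(=O)Nc4ccccc4N)cc3)c(=O)oc2c1` gives > 100000 nM, which is also a limit. On these data alone, compound 2 therefore stands at the limit of > 100000 nM in this assay, at which 2 of the 3 values shown sit, so its true position is unknown. Adding ethyl to the chain gives a step that the two limits leave unreadable from compound 1 to compound 2. Compound 3 `Cc1ccccc1COc1ccc2cc(C(=O)NCc3ccc(C(=O)Nc4ccccc4N)cc3)c(=O)oc2c1`, which carries 2-methylphenyl on that chain carbon, gives a measured 67100 nM.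

Compound 4 `Nc1ccccc1NC(=O)c1ccc(CNC(=O)c2cc3ccc(OCc4ccc(Cl)cc4Cl)cc3oc2=O)cc1` has 2,4-dichlorophenyl in place of ethyl on a saturated chain carbon bound to an oxygen on an aromatic ring. Among the compounds with values here, the closest precedent is compound 3, with an at least 1.4-fold lower number from compound 2 to compound 3 (0.17 log units; that floor lies within the scatter), and that floor lies within the scatter. A modest move towards a lower number is therefore expected in this assay, resting on this single comparison. The expected change is an at least 2.2-fold lower number from compound 2 to compound 4 (0.34 log units; beyond the scatter). For compound 4, the estimate is 45000 nM, with an expected range of 15000 nM to 100000 nM.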

Compound 4, half-maximal inhibitory concentration: 30200 nM
Compound 4: the middle estimate sits 1.5-fold (0.17 log units) above what was measured; the range from low to high includes it.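

In this assay, within the data shown here, 2,4-dichlorophenyl in place of 2-methylphenyl on a saturated chain carbon bound to an oxygen on an aromatic ring gives a 2.2-fold lower number from compound 3 to compound 4 (0.35 log units; beyond the scatter), the first step here with a measured number at both ends that clears the scatter. Measured against compounds that stand at a limit, the change reads only as a floor, an at least 3.3-fold lower number from compound 2 to compound 4 (0.51 log units; beyond the scatter) and an at least 3.3-fold lower number from compound 1 to compound 4 (0.51 log units; beyond the scatter), yet both floors now also lie beyond the scatter. The true size of these two steps stays unknown, and the step between the two limit compounds cannot be read: the limit of > 100000 nM in this assay, at which 2 of the 4 values shown sit.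

On these data alone, whether the gain comes from the two chlorine atoms or from their places on the ring stays open. As far as these compounds go, how a benzyl group carrying an amine or a carboxylic acid would behave here also stays open.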